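From sulfamoyl to 4-methylpiperazin-1-yl

The source may hold more compounds than are shown below. What is called first, only, known or untested is meant among the compounds shown, and "the series" means these compounds.

Compound 1 `NS(=O)(=O)c1ccc(Nc2nccc(Nc3ccc4nc[nH]c4c3)n2)cc1`: > 25000 nM (a limit)
Compound 2 `NS(=O)(=O)c1ccc(Nc2nccc(Nc3ccc4cn[nH]c4c3)n2)cc1`: 22000 nM

Among the compounds with values here, in an ADME assay on HepG2 cells (Homo sapiens) for inhibition, read by fluorescence and resazurin assay, with a stated time of 72 h (a lower number here means a stronger inhibitor, a higher number a weaker inhibitor), compound 2 gives 22000 nM, the only actual number so far. Compound 1 gives > 25000 nM, which is a limit of the assay and not a number. Within the data shown here, the one measured step, an at least 1.1-fold lower number from compound 1 to compound 2 (0.05 log units; that floor lies within the scatter), lies within the scatter and changes a different group, so it offers little guidance here. Compound 3 `CN1CCN(c2ccc(Nc3nccc(Nc4ccc5cn[nH]c5c4)n3)cc2)CC1` carries 4-methylpiperazin-1-yl in place of sulfamoyl on an aromatic carbon. With compound 2 at 22000 nM, more room is expected towards a lower number than a higher one. The expected change is a 3.7-fold lower number from compound 2 to compound 3 (0.56 log units; beyond the scatter), and this estimate is uncertain. For compound 3, the estimated value is 6000 nM, with an expected range of 1200 nM to 25000 nM.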

Compound 3, half-maximal inhibitory concentration: 7000 nM
Compound 3: middle estimate off by 1.2-fold (0.07 log units), on the low side; measured number inside the range.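

In this assay, putting 4-methylpiperazin-1-yl in place of sulfamoyl gives a 3.1-fold lower number from compound 2 to compound 3 (0.50 log units; beyond the scatter). This is the first step beyond the scatter among the compounds shown, so the group on this aromatic carbon, para to a large group, can shift the number, though only modestly. The entering group has more heavy atoms and a ring and lacks the hydrogen-bond donor of sulfamoyl, and this single step cannot separate those differences.

Going by these compounds, whether a simple amine or a carboxylic acid here would move the number further stays open. Compound 1 gives a limit and not a number: the limit of > 25000 nM in this assay, at which 1 of the 3 values shown sits.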